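The source may report more compounds than this note shows. Statements on the series, on what has been measured and on what is new or still open speak of the compounds shown alone.

The measured compounds are:
Compound 1 `COc1cc(N2C(N)=C(C#N)C(c3ccc(OC)c4ccccc34)C3=C2CC(C)(C)CC3=O)cc(OC)c1OC` with 40%
Compound 2 `COc1cc(N2C(N)=C(C#N)C(c3ccccc3Cl)C3=C2CC(C)(C)CC3=O)cc(OC)c1OC` with 20%
Compound 3 `COc1cc(N2C(N)=C(C#N)C(c3c(OC)ccc4ccccc34)C3=C2CC(C)(C)CC3=O)cc(OC)c1OC` with 10%

In a functional assay on Ehrlich cells (Mus musculus) for cytotoxicity, tested at 50 ug/mL (a higher number here means a stronger effect of the compound at the concentration tested, a lower number a weaker effect), compound 1 stands highest of the three numbers; compound 2 lies nearest and compound 3 furthest, both beyond the scatter. Compound 4 `COc1cc(N2C(N)=C(C#N)C(/C=C/c3ccccc3)C3=C2CC(C)(C)CC3=O)cc(OC)c1OC` differs from compound 1 at the same position that varies across the measured set: 2-phenylethenyl in place of 4-methoxynaphthalen-1-yl on a saturated ring carbon. Within the data shown here, no measured step carries this exact change. The two steps that leave compound 1 both point downward, a number 20 percentage points lower from compound 1 to compound 2 (beyond the scatter) and a number 30 percentage points lower from compound 1 to compound 3 (beyond the scatter), while the step of a number 10 percentage points lower from compound 2 to compound 3 (within the scatter) stays within the scatter. On this basis compound 4 is expected to fall modestly below compound 1, a number 20 percentage points lower from compound 1 to compound 4 (beyond the scatter). The estimate for compound 4 is 20%, with a range from 5% to 40%.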

Compound 4, a percentage reported as activity, at one concentration (the size of the read-out at that concentration, not a potency): 30%
Beside the measured number, compound 4's estimate is 10 percentage points below it; low and high end bracket the measured number.
By their numbers in this assay, from the lowest: compounds 3, 2, 4 and 1 (each within the scatter of the next, the first and the last beyond it).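

For this assay the set now holds a group with a double bond outside aromatic rings at this saturated ring carbon, and 2-phenylethenyl shows a number 10 percentage points lower from compound 1 to compound 4 (within the scatter) and a number 10 percentage points higher from compound 2 to compound 4 (within the scatter), so it does not separate from either group. Among these compounds, it does separate from 2-methoxynaphthalen-1-yl, with a number 20 percentage points higher from compound 3 to compound 4 (beyond the scatter) as the only new step beyond the scatter. Nothing available explains these differences. As far as these compounds go, whether an amine or a carboxylic acid on the phenyl ring of the 2-phenylethenyl group, or a longer chain in its place, would shift the read-out stays open.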